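A few compounds are considered here, and "the series" means these few. Any claim that something is new, unique, unknown or untested is made for them only; others in the source may bear on it.

Of the compounds shown here, three have so far been measured in a functional assay on SK-MEL-5 cells (Homo sapiens); a lower number here means a stronger inhibitor of growth, a higher number a weaker inhibitor of growth. Compound 1 `Oc1cc(-c2ccc(Cl)cc2)nc2ncccc12` gives 28800 nM. Compound 2 `Cc1ccnc2nc(-c3ccc(Cl)cc3)cc(O)c12` carries one more methyl group on the shared core, and in this assay compound 2 gives 3470 nM. The step between these two, an 8.3-fold higher number from compound 2 to compound 1 (0.92 log units; beyond the scatter), is hydrogen in place of methyl on an aromatic carbon. Compound 3 `COc1ccccc1-c1cc(O)c2ccc(C)nc2n1` differs from compound 2 in more than one place, and the difference between the two cores is not broken down here; in this assay compound 3 gives 51300 nM, the highest of the three numbers, with compound 1 within the scatter of it and compound 2 beyond it.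

Compound 4 `COc1ccccc1-c1cc(O)c2cccnc2n1` has not yet been measured. It differs from compound 3 by hydrogen in place of methyl on an aromatic carbon. Among the measured compounds shown here, this is the same kind of change as the one from compound 2 to compound 1, but not the same change: there the methyl sat ortho to a fused ring and opposite the ring nitrogen, whereas here it sits next to the ring nitrogen and para to a fused ring. For the measured compounds named here, the only measured step of this kind, an 8.3-fold higher number from compound 2 to compound 1 (0.92 log units; beyond the scatter), is the ground for the expectation that the number will rise again, though the different surroundings of the methyl leave the size uncertain; a step of about a 1.9-fold higher number from compound 3 to compound 4 (0.29 log units; within the scatter) is expected. Compound 4 is therefore estimated at 100000 nM, with a likely range from 30000 nM to 300000 nM.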

Compound 4, concentration for 50% growth inhibition: 31600 nM
Compound 4: the middle estimate sits 3.2-fold (0.50 log units) above what was measured; the range from low to high includes it.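

Taking away the methyl and putting hydrogen in its place, on an aromatic carbon next to the ring nitrogen, gives a 1.6-fold lower number from compound 3 to compound 4 (0.21 log units; within the scatter), so compound 3 and compound 4 cannot be told apart in this assay. This change therefore does not carry over from one core to the other with the same size, and the gap between the two results is larger than repeated measurements would explain: the same change on two cores in this assay, an 8.3-fold higher number (0.92 log units; beyond the scatter) from compound 2 to compound 1 and a 1.6-fold lower number (0.21 log units; within the scatter) from compound 3 to compound 4, 13-fold (1.13 log units) apart, beyond the scatter of two such steps

Among the compounds shown here, the comparison rests on only two pairs, which differ both in where the methyl sits and in the rest of the structure, so it does not show which of these sets the size of the step, nor how a third core would respond.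

Still open, going by these compounds, is whether the same core would respond differently to a methyl at each of the two places, a comparison that would separate the place of the group from the rest of the structure. The compounds shown also leave open how a group other than methyl or hydrogen at these carbons, such as an ethyl group, an amine or a carboxylic acid, would change the number in this assay.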